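A Chloro Group Added to Compound 2

The source may hold more compounds than are shown below. What is called first, only, known or untested is meant among the compounds shown, and "the series" means these compounds.

Compound 1 `CN(C)/C=C/C(=O)c1ccc2c(c1)CCCC2`: 29.3 ug/mL
Compound 2 `O=C(/C=C\Nc1ccccc1)c1ccc2c(c1)CCCC2`: 32.2 ug/mL

Both compounds were tested in a functional assay on MCF7 cells (Homo sapiens) for cytotoxicity, read by MTT assay, with a stated time of 48 h; on this read-out higher numbers stand for weaker inhibition and lower numbers for stronger inhibition. Compound 2 gives 32.2 ug/mL and compound 1 gives 29.3 ug/mL, two numbers that lie within the usual scatter of each other. On this read-out, the pair cannot be told apart.

Compound 3 `O=C(/C=C\Nc1ccc(Cl)cc1)c1ccc2c(c1)CCCC2` is compound 2 with one change: chloro in place of hydrogen on an aromatic carbon, para to a large group, so that phenyl becomes 4-chlorophenyl (chloro in place of hydrogen on an aromatic carbon).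

For the measured compounds named here, no measured pair here shows what a single change does, so only a modest shift is expected. The estimated 1.5-fold lower number from compound 2 to compound 3 (0.17 log units; within the scatter) is expected to lean towards stronger inhibition, without clearly leaving the scatter. In this assay the estimate for compound 3 is 22 ug/mL (expected range 8 ug/mL to 45 ug/mL).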

Compound 3, half-maximal inhibitory concentration: 28.7 ug/mL
Estimate against measurement, compound 3: 1.3-fold (0.12 log units) below; the measured number falls inside the stated range.
By their numbers in this assay, from the lowest: compounds 3, 1 and 2 (each within the scatter of the next).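

Placing chloro on an aromatic carbon, para to a large group, gives a 1.1-fold lower number from compound 2 to compound 3 (0.05 log units; within the scatter) in this assay and provides the first direct reading of a single change in this set. At this position, therefore, the phenyl and 4-chlorophenyl versions cannot be told apart by this read-out, so adding one chlorine atom produces no measurable change in cytotoxicity against these cells. No independent measurement is available to explain this result.

Going by these compounds, it remains open whether another group in the same place, such as an amine, a methoxy group or a carboxylic acid, would produce a step beyond the scatter. On these data alone, it is also open whether chloro elsewhere on this aromatic ring, or a change to the shared core, would leave the number just as close.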